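The source may hold more compounds than are shown below. What is called first, only, known or untested is meant among the compounds shown, and "the series" means these compounds.

Measured so far:
compound 1 `Cn1cncc1CN1CC(N(CC2CCN(C(=O)Nc3ccc(Br)cc3)CC2)S(=O)(=O)c2ccccn2)Cc2cc(C#N)ccc21` gives 0.6 10^-6 cm/s in an ADME assay on Caco-2 cells (Homo sapiens) for permeability, in the apical to basolateral direction; a lower number here means that the compound crosses the layer more slowly, a higher number that the compound crosses the layer faster
compound 2 `Cn1cncc1CN1CC(N(CCn2cccc2)S(=O)(=O)c2ccccn2)Cc2cc(C#N)ccc21` gives 12.4 10^-6 cm/s
compound 3 `Cn1cnc(S(=O)(=O)N2CCC(CN(C3Cc4cc(C#N)ccc4N(Cc4cncn4C)C3)S(=O)(=O)c3ccccn3)CC2)c1` gives 0.1 10^-6 cm/s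

Compound 2 stands highest of the three numbers: compound 1 lies a step below it, and compound 3 lies furthest below, both gaps beyond the scatter. Compound 4 `Cn1cncc1CN1CC(N(CC2CCN(C(=O)C3CC3)CC2)S(=O)(=O)c2ccccn2)Cc2cc(C#N)ccc21` is not yet measured. Its change from compound 2 is 1-(cyclopropylcarbonyl)piperidin-4-yl in place of (1H-pyrrol-1-yl)methyl on a saturated chain carbon bound to a sulfonamide nitrogen. Among the measured compounds shown here, no measured step covers this exact change. For the measured compounds named here, the only measured step, a 6.0-fold lower number from compound 1 to compound 3 (0.78 log units; beyond the scatter), concerns a different position, the amine nitrogen in the ring, and shows that groups on that piperidine strongly move the number. Compound 1, which carries the same piperidinylmethyl chain, sits far below compound 2, so a large downward step is expected: an 8.3-fold lower number from compound 2 to compound 4 (0.92 log units; beyond the scatter). Compound 4 is therefore estimated at 1.5 10^-6 cm/s, with a range from 0.4 10^-6 cm/s to 5 10^-6 cm/s.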

Compound 4, apparent permeability: 0.5 10^-6 cm/s
Beside the measured number, compound 4's estimate is 3.0-fold (0.48 log units) above it, within the range that was stated.
By their numbers in this assay, from the lowest: compound 3; then compounds 4 and 1 (each within the scatter of the next); then compound 2.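

In this assay, 1-(cyclopropylcarbonyl)piperidin-4-yl in place of (1H-pyrrol-1-yl)methyl on a saturated chain carbon bound to a sulfonamide nitrogen gives a 25-fold lower number from compound 2 to compound 4 (1.39 log units; beyond the scatter). On the amine nitrogen in the ring, cyclopropylcarbonyl in place of (1-methyl-1H-imidazol-4-yl)sulfonyl gives a 5.0-fold higher number from compound 3 to compound 4 (0.70 log units; beyond the scatter), while cyclopropyl in place of (4-bromophenyl)amino on a carbonyl carbon shows only a 1.2-fold lower number from compound 1 to compound 4 (0.08 log units; within the scatter). No measurement is available to explain these steps. It remains open whether the piperidine ring itself or the groups on its nitrogen set these low numbers: no compound shown carries a free secondary amine there.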